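Aryl ether variation in a cytotoxicity screen

The compounds below may be only part of what the source reports. "The series", "measured", "known", "first", "only" and "open" are said of these compounds alone.

Compound 1 `Cc1cn(C2CCN(Cc3cccc(Oc4cccnc4)c3)CC2)c(=O)[nH]c1=O` is the reference point of the series. In an ADME assay on MRC5 cells (Homo sapiens) for cytotoxicity, read by fluorescence and resazurin assay, with a stated time of 3 days (on this read-out lower numbers stand for stronger inhibition and higher numbers for weaker inhibition), compound 1 gives > 64000 nM, which is a limit of the assay and not a number. Compound 2 `Cc1cn(C2CCN(Cc3cccc(Oc4cccc(Cl)c4)n3)CC2)c(=O)[nH]c1=O` belongs to the same set. In this assay compound 2 gives > 64000 nM, again a limit of the assay rather than a measured number. Among the measured compounds shown here, both values shown sit at the same limit (the limit of > 64000 nM in this assay, at which 2 of the 2 values shown sit), so compound 1 stands level with the only other measured compound and no ordering can be drawn between them.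

Compound 3 `Cc1cn(C2CCN(Cc3cccc(Oc4ccc(Cl)c(C(F)(F)F)c4)c3)CC2)c(=O)[nH]c1=O` has not been measured. It differs from compound 1 by 4-chloro-3-(trifluoromethyl)phenyl in place of pyridin-3-yl on an oxygen on an aromatic ring. For the measured compounds named here, no step between measured compounds is known, so no measured change can be carried over; the expectation is that compound 3 remains at the limit, with no step beyond the scatter. The step of an at least 1.0-fold lower number from compound 1 to compound 3 (0.02 log units; that floor lies within the scatter) is expected to be close to none. Compound 3 is estimated at 60000 nM, within 15000 nM to 200000 nM, and is most likely to be reported once more only as a limit.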

Compound 3, half-maximal inhibitory concentration: 5280 nM
Compound 3: the middle estimate sits 11-fold (1.06 log units) above what was measured, outside the stated range (below it).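

Notes on the aryl ether: the group on the oxygen on an aromatic ring can move the read-out in this assay off the limit, as replacing pyridin-3-yl with 4-chloro-3-(trifluoromethyl)phenyl gives an at least 12-fold lower number from compound 1 to compound 3 (1.08 log units; beyond the scatter). This single change swaps a six-membered aromatic ring with 1 hetero atom for one of carbon only and also adds the chlorine and the trifluoromethyl, so the step belongs to the whole group and not to any one of these parts. The step is only a floor, because the value of compound 1 is a limit and not a number: the limit of > 64000 nM in this assay, at which 2 of the 3 values shown sit.

The compounds shown leave open whether an unsubstituted phenyl, or a phenyl carrying only the chlorine or only the trifluoromethyl, would leave the limit as well. On these data alone, how a carboxylic acid or an amine on that ring would read in this assay also remains open.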